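Swapping an acetal side chain for cyclopentyl

A few compounds are considered here, and "the series" means these few. Any claim that something is new, unique, unknown or untested is made for them only; others in the source may bear on it.

Compound 1 `Nc1nc2cc(-c3nn(CC4OCCO4)c4ncnc(N)c34)ccc2o1`: 100 nM
Compound 2 `CCOC(Cn1nc(-c2ccc3oc(N)nc3c2)c2c(N)ncnc21)OCC`: 100 nM

In a functional assay on U-87MG ATCC cells for antiproliferative activity against U-87 MG (Homo sapiens), with a stated time of 5 days (a lower number here means that less compound is needed, a higher number that more compound is needed for the effect), compound 2 gives 100 nM, level with compound 1. The next compound, compound 3 `Nc1nc2cc(-c3nn(CC4CCCC4)c4ncnc(N)c34)ccc2o1`, keeps the shared core and changes only the side group: cyclopentyl in place of diethoxymethyl on a saturated chain carbon bound to an aromatic nitrogen. In words, cyclopentyl takes the place of diethoxymethyl on a saturated chain carbon bound to an aromatic nitrogen.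

For the measured compounds named here, only one measured step bears on this: no change at the digits printed from compound 1 to compound 2 (within the scatter). That step exchanged one oxygen-bearing group for another, whereas cyclopentyl has a ring of carbon only, so it is a weak guide. Going by the values given here, with no measured step pointing either way, no clear direction can be expected, and no shift beyond the scatter is predicted. The expected step is no change at the digits printed from compound 2 to compound 3 (within the scatter). For compound 3 the estimated value is 100 nM, with an expected range of 30 nM to 330 nM.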

Compound 3, half-maximal effective concentration: 13 nM
For compound 3 the middle estimate is 7.7-fold (0.89 log units) above the measured one, and the stated range ends above it.
By their numbers in this assay, from the lowest: compound 3; then compounds 1 and 2 (each within the scatter of the next).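

In this assay, the group on a saturated chain carbon bound to an aromatic nitrogen clearly matters: cyclopentyl gives a 7.7-fold lower number from compound 2 to compound 3 (0.89 log units; beyond the scatter), and it gives a 7.7-fold lower number from compound 1 to compound 3 (0.89 log units; beyond the scatter), so less compound is needed for the effect. The two oxygen-bearing groups, diethoxymethyl and 1,3-dioxolan-2-yl, sat level with each other, and since the latter is itself a ring, having a ring cannot alone separate these compounds; cyclopentyl differs in being a ring of carbon only, with no hydrogen-bond acceptors. Nothing available explains why the number falls with this change.

The compounds shown leave open whether the carbon ring matters or only the absence of oxygen, a question that an open carbon chain such as pentyl could help settle. Going by these compounds, how far this position tolerates other groups, such as an amine or a carboxylic acid, also remains open.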